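Chloro-to-hydrogen step across two related cores

The compounds below may be only part of what the source reports. "The series", "measured", "known", "first", "only" and "open" are said of these compounds alone.

Compound 1 `O=C1C2=C(C(=O)c3ncccc31)C1(CS2)NC(=O)N(c2ccc(Cl)cc2)C1=O`: 580 nM
Compound 2 `O=C1C2=C(C(=O)c3ncccc31)C1(CS2)NC(=O)N(c2ccccc2)C1=O`: 1700 nM
Compound 3 `O=C1NN(c2ccc(Cl)cc2)C(=O)C2(CSC3=C2C(=O)c2ncccc2C3=O)N1`: 2000 nM

In a functional assay on SF-268 cells (Homo sapiens) for antiproliferative activity, read by MTT assay, with a stated time of 96 h (a lower number here means a stronger inhibitor, a higher number a weaker inhibitor), compound 1 gives 580 nM and compound 2 gives 1700 nM; the change between them is hydrogen in place of chloro on an aromatic carbon, and it made a step of a 2.9-fold higher number from compound 1 to compound 2 (0.47 log units; beyond the scatter). Compound 3 carries a different core, and the difference between the two cores is not broken down here. In this assay compound 3 gives 2000 nM, close to compound 2 and beyond the scatter away from compound 1. Compound 4 `O=C1NN(c2ccccc2)C(=O)C2(CSC3=C2C(=O)c2ncccc2C3=O)N1` is not yet measured. It differs from compound 3 by hydrogen in place of chloro on an aromatic carbon, the same change made from compound 1 to compound 2. Given the step of a 2.9-fold higher number from compound 1 to compound 2 (0.47 log units; beyond the scatter), compound 4 is expected to show a step of about a 2.5-fold higher number from compound 3 to compound 4 (0.40 log units; beyond the scatter) in this assay. The estimated value of compound 4 is 5000 nM, likely between 2500 nM and 12000 nM.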

Compound 4, half-maximal inhibitory concentration: 2200 nM
For compound 4 the middle estimate is 2.3-fold (0.36 log units) above the measured one; measured number below the stated range.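

In this assay, the change from 4-chlorophenyl to phenyl did not carry over from one core to the other with the same size: the same change on two cores in this assay, a 2.9-fold higher number (0.47 log units; beyond the scatter) from compound 1 to compound 2 and a 1.1-fold higher number (0.04 log units; within the scatter) from compound 3 to compound 4, 2.7-fold (0.43 log units) apart, beyond the scatter of two such steps. On the second core the change gives a 1.1-fold higher number from compound 3 to compound 4 (0.04 log units; within the scatter), so the larger step seen on the first core cannot be taken as a rule for this series. With a single pair on each core, this does not show why the two steps differ, or how the change would behave on any further core.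

The compounds shown leave open whether a fluoro, a methoxy or an amine in the same place would separate the two cores in the same way. They also leave open whether the two cores would differ like this in other cell lines.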